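The compounds below may be only part of what the source reports. "The series", "measured", "known", "first", "only" and "open" are said of these compounds alone.

Measured in a functional assay on MDBK cells (Bos taurus) for cytotoxicity; a lower number here means that less compound is tolerated, a higher number that more compound is tolerated:
- Compound 1 `CO/N=C(\C#N)C(=O)NCC1=NOC(C)(C)C1`: > 100 ug/mL, a limit of the assay and not a number.
- Compound 2 `C=CCO/N=C(\C#N)C(=O)NCC1=NOC(c2ccccc2)C1`: 100 ug/mL

Going by the values given here, compound 2 gives the only actual number in this small set, 100 ug/mL. Going from compound 2 to compound 3 `C=CCO/N=C(\C#N)C(=O)NCC1=NOC(c2ccccc2)(c2ccccc2)C1`, the structure changes by phenyl in place of hydrogen on a saturated ring carbon. Among the compounds with values here, no measured step between two compounds is available as a guide, so the expectation rests on compound 2 at 100 ug/mL alone and stays loose. A small fall in the tolerated concentration is expected, with an estimated step of a 1.3-fold lower number from compound 2 to compound 3 (0.10 log units; within the scatter). For compound 3 the estimate is 80 ug/mL, with an expected range from 35 ug/mL to 100 ug/mL.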

Compound 3, half-maximal cytotoxic concentration: 100 ug/mL
Compound 3: the middle estimate sits 1.3-fold (0.10 log units) below what was measured, within the range that was stated.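

In this assay, phenyl in place of hydrogen on the saturated ring carbon next to the ring oxygen brings no change at the digits printed from compound 2 to compound 3 (within the scatter). Going by these compounds alone, this position therefore carries a second phenyl with no shift in the tolerated concentration beyond the scatter, which the earlier compounds could not show. Compound 1 offers only a limit and not a number, so it gives no comparison here: the limit of > 100 ug/mL in this assay, at which 1 of the 3 values shown sits.

Going by these compounds, whether an amine or a carboxylic acid at this ring carbon would move the tolerated concentration stays open.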